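A few compounds are considered here, and "the series" means these few. Any claim that something is new, unique, unknown or untested is made for them only; others in the source may bear on it.

Compound 1 `CC#CC(CC(=O)O)c1ccc(OCc2ccc(C(=O)N3CCN(Cc4ccccc4)CC3)s2)cc1` carries a benzyl group on the ring amine nitrogen; in a functional assay on HEK293 cells for agonist activity at Free fatty acid receptor 1 (Homo sapiens), read by fluorescence and calcium flux (a lower number here means that less compound is needed, a higher number that more compound is needed for the effect), compound 1 gives 155 nM. Compound 2 `CC#CC(CC(=O)O)c1ccc(OCc2ccc(C(=O)N3CCN(c4ccc(C)cc4)CC3)s2)cc1` replaces that benzyl with a 4-methylphenyl group, and in this assay compound 2 gives 211 nM. The step of a 1.4-fold higher number from compound 1 to compound 2 (0.13 log units; within the scatter) is within the scatter, so compound 2 sits at a number that cannot be told apart from that of compound 1. Compound 3 `CC#CC(CC(=O)O)c1ccc(OCc2ccc(C(=O)N3CCN(c4ccc(Cl)cc4)CC3)s2)cc1` is the next variation: chloro in place of methyl on an aromatic carbon. Among the compounds with values here, no measured step concerns a change of this kind on an aromatic carbon; the only measured step, from compound 1 to compound 2, swapped the whole group on the amine nitrogen and stayed within the scatter. With nothing pointing either way, the number for compound 3 in this assay is expected to stay close to that of compound 2, with a 1.1-fold lower number from compound 2 to compound 3 (0.02 log units; within the scatter) as the expected step. Compound 3 is therefore estimated at 200 nM, within a range of 90 nM to 450 nM.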

Compound 3, half-maximal effective concentration: 133 nM
Compound 3: middle estimate off by 1.5-fold (0.18 log units), on the high side; the range from low to high includes it.
By their numbers in this assay, from the lowest: compounds 3, 1 and 2 (each within the scatter of the next).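

In this assay, chloro in place of methyl on the aromatic carbon para to a large group gives a 1.6-fold lower number from compound 2 to compound 3 (0.20 log units; within the scatter) and so shows that this position takes either group without a change that can be told from the scatter. With 4-chlorophenyl in place of benzyl on the ring amine nitrogen, the comparison gives a 1.2-fold lower number from compound 1 to compound 3 (0.07 log units; within the scatter) and also stays within the scatter, so the three groups shown on that nitrogen cannot be told apart in this assay. No evidence at hand accounts for how little these numbers differ.

Going by these compounds, whether a methoxy group, an amine or a carboxylic acid at this same place would move the number beyond the scatter remains open. So does whether a longer chain in place of the benzyl on the ring amine nitrogen would do so.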